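Nitro in Place of Phenoxy on the Aromatic Ring

The source may report more compounds than this note shows. Statements on the series, on what has been measured and on what is new or still open speak of the compounds shown alone.

Compound 3 `N[C@]1(C(=O)O)[C@H]2[C@@H](C[C@H]1OCc1cccc(Oc3ccccc3)c1)[C@]2(F)C(=O)O` gives 7.15 nM in an assay on CHO cells for binding affinity to metabotropic glutamate receptor 2 (Rattus norvegicus); a higher number here means a weaker inhibitor, a lower number a stronger inhibitor. Its number sits within the scatter of both compound 1 `N[C@]1(C(=O)O)[C@H]2[C@@H](C[C@H]1OCc1ccccc1)[C@]2(F)C(=O)O`, which gives 7.14 nM, and compound 2 `N[C@]1(C(=O)O)[C@H]2[C@@H](C[C@H]1OCc1cccc(-c3ccccc3)c1)[C@]2(F)C(=O)O`, which gives 9.34 nM. Compound 4 `N[C@]1(C(=O)O)[C@H]2[C@@H](C[C@H]1OCc1cccc([N+](=O)[O-])c1)[C@]2(F)C(=O)O` differs from compound 3 by nitro in place of phenoxy on an aromatic carbon. For the measured compounds named here, two measured steps bear on this change, since both alter the same aromatic carbon: a 1.0-fold higher number from compound 1 to compound 3 (0.00 log units; within the scatter) and a 1.3-fold lower number from compound 2 to compound 3 (0.12 log units; within the scatter). Neither a phenoxy entering for hydrogen nor a phenoxy entering for phenyl moved the number beyond the scatter, so a nitro entering for phenoxy is expected to leave it there as well. Compound 4 is therefore estimated at 8 nM, with a range from 3 nM to 25 nM. The expected step is a 1.1-fold higher number from compound 3 to compound 4 (0.05 log units; within the scatter).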

Compound 4, inhibition constant: 7.87 nM
Beside the measured number, compound 4's estimate is 1.0-fold (0.01 log units) above it, within the range that was stated.
By their numbers in this assay, from the lowest: compounds 1, 3, 4 and 2 (each within the scatter of the next).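

With nitro at this aromatic carbon, the number in this assay stays within the scatter in all three new comparisons: a 1.1-fold higher number from compound 3 to compound 4 (0.04 log units; within the scatter), a 1.2-fold lower number from compound 2 to compound 4 (0.07 log units; within the scatter) and a 1.1-fold higher number from compound 1 to compound 4 (0.04 log units; within the scatter). The earlier compounds shown here showed this only for phenyl and phenoxy, each of which carries a six-membered aromatic ring, whereas nitro has no ring and fewer heavy atoms. From the compounds shown here alone, whether an amine or a carboxylic acid on this same carbon would also leave the number within the scatter remains open. Nothing available here explains why these groups give such similar numbers.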